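This account rests on a few compounds, and the source may have more. Where it says the series, first, only, none or still open, it means among the compounds named here.

Measured so far in an assay on isolated protein for displacement of a labelled ligand from Apoptosis regulator Bcl-2 (Homo sapiens), with a stated time of 15 min; a lower number here means a stronger inhibitor, a higher number a weaker inhibitor:

- compound 1 `CC1(C)CCC(CN2CCN(c3ccc(C(=O)NS(=O)(=O)c4ccc(NCC5CCOCC5)c([N+](=O)[O-])c4)c(Oc4cnc5[nH]ccc5c4)c3)CC2)=C(c2ccc(C(F)(F)F)cc2)C1`: 1.5 nM
- compound 2 `CC(C)C(=O)N1CCC(CNc2ccc(S(=O)(=O)NC(=O)c3ccc(N4CCN(CC5=C(c6ccc(C(F)(F)F)cc6)CC(C)(C)CC5)CC4)cc3Oc3cnc4[nH]ccc4c3)cc2[N+](=O)[O-])CC1`: 2.4 nM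
- compound 3 `CC1(C)CCC(CN2CCN(c3ccc(C(=O)NS(=O)(=O)c4ccc(OCC5CCOCC5)c([N+](=O)[O-])c4)c(Oc4cnc5[nH]ccc5c4)c3)CC2)=C(c2ccc(C(F)(F)F)cc2)C1`: 1 nM

Compound 3 gives the lowest number of the three in this assay; compound 1 stands within the scatter of it, and only compound 2 lies beyond that scatter, so no order can be read between compound 3 and compound 1.

Compound 4 `CCN1CCC(COc2ccc(S(=O)(=O)NC(=O)c3ccc(N4CCN(CC5=C(c6ccc(C(F)(F)F)cc6)CC(C)(C)CC5)CC4)cc3Oc3cnc4[nH]ccc4c3)cc2[N+](=O)[O-])CC1` is not yet measured. It differs from compound 3 in one place: 1-ethylpiperidin-4-yl in place of oxan-4-yl on a saturated chain carbon bound to an oxygen on an aromatic ring.

Among the measured compounds shown here, two measured steps bear on this. The swap of the ring at the same side of the molecule, from oxan-4-yl to a substituted piperidin-4-yl, gave a 1.6-fold higher number from compound 1 to compound 2 (0.20 log units; within the scatter), so a ring of that kind is tolerated at this position. The change of the link to the aromatic ring from the amino to the oxy form gave a 1.5-fold lower number from compound 1 to compound 3 (0.18 log units; within the scatter), again a small shift. Both steps stayed within the scatter, and nothing in the three compounds points to a larger effect of a nitrogen-containing ring at this position. The expected step in this assay is therefore small, a 1.4-fold higher number from compound 3 to compound 4 (0.15 log units; within the scatter), with no direction settled beyond the scatter.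

Compound 4 is estimated at 1.4 nM, with a range of 0.5 nM to 4 nM.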

Compound 4, half-maximal inhibitory concentration: 0.5 nM
For compound 4 the middle estimate is 2.8-fold (0.45 log units) above the measured one; low and high end bracket the measured number.
By their numbers in this assay, from the lowest: compounds 4, 3, 1 and 2 (each within the scatter of the next, the first and the last beyond it).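

In this assay, replacing oxan-4-yl with 1-ethylpiperidin-4-yl on a saturated chain carbon bound to an oxygen on an aromatic ring gives a 2.0-fold lower number from compound 3 to compound 4 (0.30 log units; within the scatter) and shows that this larger nitrogen ring, with its ethyl group, is accepted on the oxygen-linked chain as well. Among the compounds shown here, the full change from ((oxan-4-yl)methyl)amino to (1-ethylpiperidin-4-yl)methoxy gives a 3.0-fold lower number from compound 1 to compound 4 (0.48 log units; beyond the scatter) and is the first step on this group to pass the scatter, although the change of link alone gives a 1.5-fold lower number from compound 1 to compound 3 (0.18 log units; within the scatter) and the ring change above also stays within it. No measurement on hand accounts for the size of either step.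

The compounds shown do not separate the contributions of ring and link, since 1-ethylpiperidin-4-yl appears only on the oxygen-linked chain and 1-(isopropylcarbonyl)piperidin-4-yl only on the nitrogen-linked one. They also leave open how the number responds to a piperidine with only hydrogen on its nitrogen, to a propyl group in place of ethyl, or to an open-chain dimethylamino group in place of the ring.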